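This account rests on a few compounds, and the source may have more. Where it says the series, first, only, none or still open, it means among the compounds named here.

Working notes on the series. Compound 1 `O=C(CCN1C(=O)CSc2ccccc21)N1CCN(c2ccc(C(F)(F)F)cc2)CC1` gives 1000 nM in a functional assay on MDA-MB-231 cells (Homo sapiens) for inhibition, read by sulforhodamine B assay, with a stated time of 48 h; a higher number here means a weaker inhibitor of growth, a lower number a stronger inhibitor of growth. Compound 2 `O=C(CCN1C(=O)CSc2ccccc21)N1CCN(c2ccccc2F)CC1` gives 1600 nM in this assay. The only difference between them is 2-fluorophenyl in place of 4-(trifluoromethyl)phenyl on an amine nitrogen in a ring, and that change made a 1.6-fold higher number from compound 1 to compound 2 (0.20 log units; within the scatter). Compound 3 `O=C(CCN1C(=O)CSc2ccccc21)NCCCN1CCN(c2ccc(C(F)(F)F)cc2)CC1` carries a different core; how its core differs from that of compound 1 is not broken down here. In this assay compound 3 gives 20400 nM, the highest of the three numbers, beyond the scatter from both compound 1 and compound 2.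

Compound 4 `O=C(CCN1C(=O)CSc2ccccc21)NCCCN1CCN(c2ccccc2F)CC1` is not yet measured. It differs from compound 3 by 2-fluorophenyl in place of 4-(trifluoromethyl)phenyl on an amine nitrogen in a ring, the same change that separates compound 1 from compound 2, made at the same place on the same six-membered non-aromatic ring with 2 nitrogen. On the core of compound 1 that change stayed within the scatter, so the step in this assay from compound 3 to compound 4 is expected to be of similar size, a 1.4-fold higher number from compound 3 to compound 4 (0.14 log units; within the scatter), resting on a 1.6-fold higher number from compound 1 to compound 2 (0.20 log units; within the scatter) and on compound 3 giving 20400 nM. Compound 4 is therefore estimated at 28000 nM, with a range of 12000 nM to 70000 nM.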

Compound 4, concentration for 50% growth inhibition: 4600 nM
Compound 4: the middle estimate sits 6.1-fold (0.78 log units) above what was measured, and the stated range ends above it.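

In this assay, 2-fluorophenyl in place of 4-(trifluoromethyl)phenyl gives a 4.4-fold lower number from compound 3 to compound 4 (0.65 log units; beyond the scatter). The change therefore does not carry a fixed step from one core to the other: the same change on two cores in this assay, a 1.6-fold higher number (0.20 log units; within the scatter) from compound 1 to compound 2 and a 4.4-fold lower number (0.65 log units; beyond the scatter) from compound 3 to compound 4, 7.1-fold (0.85 log units) apart, beyond the scatter of two such steps. This shows that, for these two cores, the size of the step cannot be taken from one core and applied to the other; with one pair on each core, it does not show how the change would behave on any further core, or which feature of the core difference goes with the gap.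

The compounds shown leave open whether the gap between the cores also appears with other groups on the ring nitrogen, such as an unsubstituted phenyl or a benzyl group. They also leave open how the step would behave with a longer chain in the core of compound 3.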